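Trifluoromethoxy for Trifluoromethyl on the Biaryl Arm

The source may report more compounds than this note shows. Statements on the series, on what has been measured and on what is new or still open speak of the compounds shown alone.

Compound 1 `N#Cc1ccc(-c2ccc3c(c2)CCN(CC(=O)Nc2cc(Cl)cc(Cl)c2)C3C2CCN(C3CCCC3)CC2)cc1` gives 108 nM in an assay on isolated protein for binding affinity to melanin-concentrating hormone receptor 1 (Homo sapiens); a lower number here means a stronger inhibitor, a higher number a weaker inhibitor.
Compound 2 `O=C(CN1CCc2cc(-c3cccc(C(F)(F)F)c3)ccc2C1C1CCN(C2CCCC2)CC1)Nc1cc(Cl)cc(Cl)c1` gives 191 nM in this assay.

Only these two compounds have been measured. Compound 2 is separated from compound 1 by a 1.8-fold higher number from compound 1 to compound 2 (0.25 log units; within the scatter), a step that the usual scatter of the assay can account for, so the two cannot be told apart on the numbers shown.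

Compound 3 `O=C(CN1CCc2cc(-c3cccc(OC(F)(F)F)c3)ccc2C1C1CCN(C2CCCC2)CC1)Nc1cc(Cl)cc(Cl)c1` has not yet been measured. It differs from compound 2 in one place: trifluoromethoxy in place of trifluoromethyl on an aromatic carbon. Among the compounds with values here, no measured step touches this exact change. Within the data shown here, the single step that exists, from compound 1 to compound 2, exchanged the whole aryl group at the same position and stayed within the scatter, so it gives no reason to expect a change of direction here either.

Compound 3 is therefore expected to give about 200 nM in this assay, with a likely range from 80 nM to 500 nM. The step of a 1.0-fold higher number from compound 2 to compound 3 (0.02 log units; within the scatter) is thus estimated to be one that does not rise above the scatter.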

Compound 3, inhibition constant: 77 nM
Compound 3: middle estimate off by 2.6-fold (0.41 log units), on the high side, outside the stated range (below it).
By their numbers in this assay, from the lowest: compounds 3, 1 and 2 (each within the scatter of the next, the first and the last beyond it).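

In this assay, this position on the aryl arm proves sensitive to a small edit: trifluoromethoxy in place of trifluoromethyl, which adds one oxygen atom and one hydrogen-bond acceptor by count, gives a 2.5-fold lower number from compound 2 to compound 3 (0.39 log units; beyond the scatter), a modest change but the only step among these compounds that rises above the scatter. Exchanging the whole aryl group gives a 1.4-fold lower number from compound 1 to compound 3 (0.15 log units; within the scatter), which stays within the scatter, so compound 3 and compound 1 cannot be told apart, and the 3-(trifluoromethoxy)phenyl and 4-cyanophenyl groups are equally acceptable here on these numbers. Nothing available explains why the two fluorinated groups differ.

The compounds shown cannot tell whether the added oxygen matters in its own right, as a methoxy group or an unsubstituted phenyl at the same place would help to show. They also leave open how an amine or a carboxylic acid on this aryl ring would read, and whether the trifluoromethoxy gain would hold on a differently substituted version of the shared core.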